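Compound 4: 4-methyl-3-nitrophenyl on the sulfonyl sulfur

A few compounds are considered here, and "the series" means these few. Any claim that something is new, unique, unknown or untested is made for them only; others in the source may bear on it.

Compound 3 `COc1ccc(-c2cc(=O)c3c(OC)cc(OC)cc3n2S(=O)(=O)c2cccc([N+](=O)[O-])c2)cc1` carries a 3-nitrophenyl on the sulfonyl sulfur of the shared core. In an ADME assay on BJ cells (Homo sapiens) for antiproliferative activity, with a stated time of 72 h (on this read-out higher numbers stand for an effect only at larger amounts of compound and lower numbers for an effect already at smaller amounts), compound 3 reaches only a limit, > 39600 nM, and no number. Compound 1 `COc1ccc(-c2cc(=O)c3c(OC)cc(OC)cc3n2S(=O)(=O)c2ccc(C=O)cc2)cc1` and compound 2 `COc1ccc(-c2cc(=O)c3c(OC)cc(OC)cc3n2S(=O)(=O)c2ccc([N+](=O)[O-])cc2)cc1` stand alongside it in the same series. In this assay compound 1 also gives a limit, > 34400 nM. In this assay compound 2 likewise gives a limit, > 29300 nM. All three values are limits of this assay, so compound 3 cannot be placed above or below the other two.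

Compound 4 `COc1ccc(-c2cc(=O)c3c(OC)cc(OC)cc3n2S(=O)(=O)c2ccc(C)c([N+](=O)[O-])c2)cc1` differs from compound 3 by methyl in place of hydrogen on an aromatic carbon. The measured steps that bear on this change all run between limits: a step that the two limits leave unreadable from compound 2 to compound 3, a step that the two limits leave unreadable from compound 1 to compound 3 and a step that the two limits leave unreadable from compound 1 to compound 2 leave their size unreadable. Among the measured compounds shown here, nothing among the measured compounds shows a change on the sulfonyl aryl producing a readable number in this assay. For compound 4 the expected outcome is that this assay again reports a limit rather than a number. The step from compound 3 to compound 4 is expected to be a step that the limit leaves unreadable from compound 3 to compound 4, no step beyond the scatter. The estimate for compound 4 in this assay is 40000 nM, with a range from 20000 nM to 80000 nM.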

Compound 4, half-maximal effective concentration: > 51700 nM
Compound 4 gave a limit, no number (the forecaster's own chance of this, stated with the estimate: 85%); middle value at least 1.2-fold (0.11 log units) away from the limit.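

In this assay compound 4 gives only a limit, as do compound 1, compound 2 and compound 3, so the steps linking compound 4 to compound 1, compound 2 and compound 3 cannot be read. The compounds shown leave open whether any change on the sulfonyl aryl alters the half-maximal effective concentration.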